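Moving the Carboxyl Around the Benzyl Ring

The compounds below may be only part of what the source reports. "The series", "measured", "known", "first", "only" and "open" are said of these compounds alone.

Compound 3 `COc1ccc(CCCCCCCCOc2ccc(CSCc3ccc(C(=O)O)cc3)nc2/C=C/C(=O)O)cc1` gives 175 nM in a functional assay on the whole organism with Homo sapiens as the target, read by calcium flux; a higher number here means a weaker inhibitor, a lower number a stronger inhibitor. Among the three compounds measured so far, compound 3 carries the second highest number. Its nearest neighbour is compound 1 `COc1ccc(CCCCCCCCOc2ccc(CSCc3cccc(C(=O)O)c3)nc2/C=C/C(=O)O)cc1`, which gives 131 nM in this assay; the step of a 1.3-fold higher number from compound 1 to compound 3 (0.13 log units; within the scatter) lies within the scatter, so these two cannot be told apart. The furthest is compound 2 `COc1ccc(CCCCCCCCOc2ccc(C[S+]([O-])Cc3cccc(C(=O)O)c3)nc2/C=C/C(=O)O)cc1`, which gives 3300 nM in this assay; the step of a 19-fold lower number from compound 2 to compound 3 (1.28 log units; beyond the scatter) is large, as is the related step of a 25-fold higher number from compound 1 to compound 2 (1.40 log units; beyond the scatter).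

Compound 4 `COc1ccc(CCCCCCCCOc2ccc(CSCc3ccccc3C(=O)O)nc2/C=C/C(=O)O)cc1` has not yet been measured in this assay. It differs from compound 3 by 2-carboxyphenyl in place of 4-carboxyphenyl on a saturated chain carbon bound to a sulfur. For the measured compounds named here, the only measured step that bears on this change is a 1.3-fold higher number from compound 1 to compound 3 (0.13 log units; within the scatter), which moved the same carboxyl from the 3-position to the 4-position and stayed within the scatter. Going by the values given here, no measured pair speaks to the 2-position directly, so the series offers no precedent for a large step here. The expectation for compound 4 is therefore a step of a 1.7-fold higher number from compound 3 to compound 4 (0.23 log units; within the scatter), most likely not beyond the scatter, with the wider range allowing for a weaker result. The estimate for compound 4 is 300 nM, expected to fall between 100 nM and 1200 nM.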

Compound 4, half-maximal inhibitory concentration: 710 nM
Compound 4: the middle estimate sits 2.4-fold (0.37 log units) below what was measured; the range from low to high includes it.
By their numbers in this assay, from the lowest: compounds 1 and 3 (each within the scatter of the next); then compound 4; then compound 2.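

Only 2-carboxyphenyl, on a saturated chain carbon bound to a sulfur, separates from the other two carboxyl arrangements in this assay, with modest steps on both sides (a 4.1-fold higher number from compound 3 to compound 4 (0.61 log units; beyond the scatter); a 5.4-fold higher number from compound 1 to compound 4 (0.73 log units; beyond the scatter)), while 4-carboxyphenyl and 3-carboxyphenyl remain indistinguishable (a 1.3-fold higher number from compound 1 to compound 3 (0.13 log units; within the scatter)). Where the carboxyl sits on this ring therefore does matter, but not at every place, and the series now has a change of place that lies beyond the scatter, though compound 4 stays modestly short of the highest number (a 4.6-fold lower number from compound 2 to compound 4 (0.67 log units; beyond the scatter)). Nothing measured here accounts for the weaker result of 2-carboxyphenyl.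

The compounds shown leave open whether the shift belongs to the carboxylic acid itself or to any group at that place, which 2-methoxycarbonylphenyl, 2-methylphenyl or plain phenyl on the same saturated chain carbon could separate. Also open, as far as these compounds go, is whether 2-carboxyphenyl would carry the same cost on a core with a shorter chain.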